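The source may report more compounds than this note shows. Statements on the series, on what has been measured and on what is new or still open speak of the compounds shown alone.

Measured so far:
compound 1, `Cn1cccc1-c1ccccc1NCC1=NCCN1`: 103%
compound 2, `Cc1n[nH]c(-c2ccccc2NCC2=NCCN2)n1`: 87%

In a functional assay with Alpha-1A adrenergic receptor (Homo sapiens) as the target, read by calcium flux (on this read-out lower numbers stand for smaller maximal responses and higher numbers for larger maximal responses), compound 2 gives the lower of the two numbers; the step of a number 16 percentage points lower from compound 1 to compound 2 (beyond the scatter) lies beyond the scatter. Compound 3, `Cn1cc(-c2ccccc2NCC2=NCCN2)cn1`, is not yet measured. The change is 1-methyl-1H-pyrazol-4-yl in place of 3-methyl-1H-1,2,4-triazol-5-yl on an aromatic carbon. Among the measured compounds shown here, the only measured step that bears on it is the exchange of one five-membered aromatic ring for another at the same place, which gave a number 16 percentage points lower from compound 1 to compound 2 (beyond the scatter). A change of similar kind, going the other way, is expected to give a small to modest rise in this assay, a number 8 percentage points higher from compound 2 to compound 3 (within the scatter). Compound 3 is estimated at 95%, within 80% to 110%.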

Compound 3, largest response reached (reported as maximal response), in percent of the reference or control that the assay uses: 39%
Beside the measured number, compound 3's estimate is 56 percentage points above it, outside the stated range (below it).
By their numbers in this assay, from the lowest: compound 3; then compound 2; then compound 1.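

In this assay, the identity of the five-membered aromatic ring at this place matters far more than the first exchange suggested: 1-methyl-1H-pyrazol-4-yl gives a number 48 percentage points lower from compound 2 to compound 3 (beyond the scatter) and a number 64 percentage points lower from compound 1 to compound 3 (beyond the scatter). The 3-methyl-1H-1,2,4-triazol-5-yl and 1-methyl-1H-pyrazol-4-yl groups both hold 6 heavy atoms, so that count does not separate their results. Nothing available explains the drop. Still open, from the compounds shown here alone, is whether the lower response depends on the ring's point of attachment or on its methyl group. A 1H-pyrazol-4-yl without the methyl, or a phenyl ring at the same place, would bear on this.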